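Aryl swap on the side chain: compound 2 to compound 4

The source may hold more compounds than are shown below. What is called first, only, known or untested is meant among the compounds shown, and "the series" means these compounds.

Measured so far, with the value in a functional assay on HeLa cells (Homo sapiens) for cytotoxicity, read by WST assay, with a stated time of 48 h; a lower number here means a stronger inhibitor, a higher number a weaker inhibitor:
compound 1 `COc1ccc(/C=C/C[C@@H]2C[C@@H]([C@@H](O)c3ccc(OC)c(OC)c3)CO[C@H]2c2ccc(OC)c(OC)c2)cc1` gives 17100 nM;
compound 2 `COc1cccc(/C=C/C[C@H]2C[C@@H]([C@@H](O)c3ccccc3)CO[C@@H]2c2ccccc2)c1` gives 10900 nM;
compound 3 `COc1ccc(/C=C/C[C@@H]2C[C@H]([C@H](O)c3ccc(OC)c(OC)c3)CO[C@H]2c2ccc(OC)c(OC)c2)cc1OC` gives 28700 nM.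

Compound 2 holds the lowest of the three numbers shown. Compound 1 stands nearest, within the scatter, so the two cannot be told apart in this assay. Compound 3 stands furthest, beyond the scatter, and this is the only gap among the three that counts as a real one.

Compound 4 `O[C@@H](c1ccccc1)[C@H]1CO[C@H](c2ccccc2)[C@@H](C/C=C/c2ccccc2F)C1` has not yet been measured in this assay. It differs from compound 2 in one place: 2-fluorophenyl in place of 3-methoxyphenyl on a double-bonded chain carbon bound to a double-bonded chain carbon. Among the measured compounds shown here, no pair of measured compounds differs in one place, so nothing among them shows what such an aryl swap does to the number. All three measured values sit in the same weak region. The expected step is a 1.0-fold higher number from compound 2 to compound 4 (0.00 log units; within the scatter), which is within the scatter, in no particular direction. Compound 4 is therefore estimated at 11000 nM, with a range from 4000 nM to 30000 nM.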

Compound 4, half-maximal inhibitory concentration: 9730 nM
Compound 4: middle estimate off by 1.1-fold (0.05 log units), on the high side; the measured number falls inside the stated range.
By their numbers in this assay, from the lowest: compounds 4, 2, 1 and 3 (each within the scatter of the next, the first and the last beyond it).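

In this assay, among the compounds shown here, 2-fluorophenyl in place of 3-methoxyphenyl on a double-bonded chain carbon bound to a double-bonded chain carbon gives a 1.1-fold lower number from compound 2 to compound 4 (0.05 log units; within the scatter), the first step that can be read at a single place. At this position, then, the methoxy group with its one hydrogen-bond acceptor can give way to fluorine with no shift that can be told from the scatter. No measurement at hand bears on why the number holds.

Going by these compounds, one swap does not show whether this position accepts aryl groups in general, and an aminophenyl or a carboxyphenyl on the chain remains untested here. Also open, on these data alone, is whether any change at this place, such as a longer chain carrying the aryl group, moves the number beyond the scatter.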